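The source may report more compounds than this note shows. Statements on the series, on what has been measured and on what is new or still open speak of the compounds shown alone.

Measured so far:
- compound 1, `Cc1nn(-c2ncnc3nc[nH]c23)c2c1C(C(=O)NCc1ccccc1)CC(=O)N2`: 5 nM
- compound 2, `Cc1nn(-c2ncnc3nc[nH]c23)c2c1C(OCc1ccc(C(C)C)cc1)CC(=O)N2`: 5 nM
- compound 3, `Cc1nn(-c2ncnc3nc[nH]c23)c2c1C(c1ccc(OC(C)C)cc1)CC(=O)N2`: 18 nM

These three compounds share one core and differ only in the group on a saturated ring carbon. In a functional assay on HEK293 cells for agonist activity at G-protein coupled receptor 39 (Homo sapiens), read by scintillation proximity assay and inositol phosphate accumulation, with a stated time of 75 min, in the presence of a further agent that is not named here (on this read-out lower numbers stand for an effect already at smaller amounts and higher numbers for an effect only at larger amounts of compound), compound 3 gives the highest number of the three, and the steps that separate it from compound 1 and from compound 2 both lie beyond the scatter. For the measured compounds named here, the one single-point change with a measured step is a 3.6-fold higher number from compound 1 to compound 3 (0.56 log units; beyond the scatter).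

Compound 4, `Cc1nn(-c2ncnc3nc[nH]c23)c2c1C(OCc1ccc(C#N)cc1)CC(=O)N2`, has not been measured. It differs from compound 3 in one place: (4-cyanobenzyl)oxy in place of 4-isopropoxyphenyl on a saturated ring carbon. Going by the values given here, no measured step covers exactly this change. Compound 2 carries a (4-isopropylbenzyl)oxy group on the same carbon and gives 5 nM, a lower number than compound 3, which suggests that a benzyloxy-type group on this carbon is compatible with a low number. Among the compounds with values here, the nitrile of compound 4 has no counterpart among the measured compounds, so the estimate is uncertain. The expected step is a 2.3-fold lower number from compound 3 to compound 4 (0.35 log units; beyond the scatter), and for compound 4 the estimated value in this assay is 8 nM with a range of 2 nM to 40 nM.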

Compound 4, half-maximal effective concentration: 4 nM
Beside the measured number, compound 4's estimate is 2.0-fold (0.30 log units) above it; low and high end bracket the measured number.
By their numbers in this assay, from the lowest: compounds 4, 1 and 2 (each within the scatter of the next); then compound 3.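

In this assay the swap on the saturated ring carbon gives a 4.5-fold lower number from compound 3 to compound 4 (0.65 log units; beyond the scatter) and so shows a low number for a benzyloxy-type group carrying a nitrile, not only for one carrying isopropyl. On the aromatic carbon of that group, the change gives a 1.3-fold lower number from compound 2 to compound 4 (0.10 log units; within the scatter) and leaves cyano and isopropyl indistinguishable on this read-out, while the replacement of benzylcarbamoyl gives a 1.3-fold lower number from compound 1 to compound 4 (0.10 log units; within the scatter) and leaves those two groups equally indistinguishable. Nothing available explains why these groups give the numbers they do.

Going by these compounds, whether an amine or a carboxylic acid in place of the cyano would keep the number this low stays open. So does the outcome of a longer chain in place of the (4-cyanobenzyl)oxy group on the saturated ring carbon.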